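Methoxy Additions on a Shared Core Against Lung Cells

This account rests on a few compounds, and the source may have more. Where it says the series, first, only, none or still open, it means among the compounds named here.

Compound 1, `COc1cccc(-c2ncnn2-c2cc(OC)c(OC)c(OC)c2)c1`: > 10000 nM
Compound 2, `COc1cc(-c2ncnn2-c2ccccc2)cc(OC)c1OC`: > 10000 nM
Compound 3, `COc1cc(-n2ncnc2-c2ccccc2)cc(OC)c1OC`: > 10000 nM

In a functional assay on A549 cells (Homo sapiens) for antiproliferative activity, read by MTT assay, with a stated time of 72 h (a higher number here means a weaker inhibitor, a lower number a stronger inhibitor), compound 1 gives > 10000 nM, which is a limit of the assay rather than a number. Compound 2 likewise gives only a limit, > 10000 nM. Compound 3 also sits at a limit, > 10000 nM. The difference between the cores of compound 2 and compound 3 is not broken down here. Compound 1 differs from compound 3 by methoxy in place of hydrogen on an aromatic carbon; the step that the two limits leave unreadable from compound 3 to compound 1 cannot be read because both values sit at the limit of > 10000 nM in this assay, at which 3 of the 3 values shown sit.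

Compound 4, `COc1ccc(-n2ncnc2-c2cc(OC)c(OC)c(OC)c2)cc1`, has not yet been measured in this assay. It differs from compound 2 by methoxy in place of hydrogen on an aromatic carbon. This is the same kind of change as from compound 3 to compound 1, though there the methoxy sits meta to a large group and here para to a large group. With the earlier step unreadable and every shown value at the limit of > 10000 nM in this assay, at which 3 of the 3 values shown sit, the expected step is a step that the limit leaves unreadable from compound 2 to compound 4, most likely ending again at a limit. Compound 4 is expected to give about 15000 nM, between 5000 nM and 60000 nM, because all three shown values sit at the limit of > 10000 nM in this assay, at which 3 of the 3 values shown sit.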

Compound 4, half-maximal inhibitory concentration: > 10000 nM
Compound 4: only a limit was reported (the forecaster's own chance of this, stated with the estimate: 85%); the middle value lies beyond the limit too.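

No new step can be read between compound 2 and compound 4 in this assay, because both values are limits and not numbers: the limit of > 10000 nM in this assay, at which 4 of the 4 values shown sit.

The compounds shown leave open whether adding a methoxy group changes the activity at all, and what change to the shared core would bring a value within the readable range.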